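Indole Amides Bearing a Methoxyphenyl-Piperazine Chain

A few compounds are considered here, and "the series" means these few. Any claim that something is new, unique, unknown or untested is made for them only; others in the source may bear on it.

Compounds measured so far:
compound 1 `COc1ccccc1N1CCN(CCCNC(=O)Cc2c[nH]c3ccccc23)CC1` with 513 nM
compound 2 `COc1ccccc1N1CCN(CCCNC(=O)CCc2c[nH]c3ccccc23)CC1` with 219 nM
compound 3 `COc1ccc2[nH]c(C(=O)NCCCN3CCN(c4ccccc4OC)CC3)cc2c1` with 1450 nM

In an assay on isolated protein (spleen, strain Sprague-Dawley) for antagonist activity at Alpha-1B adrenergic receptor (Rattus norvegicus), with a stated time of 20 min (a higher number here means weaker binding, a lower number tighter binding), compound 1 stands second highest of the three numbers, closer to compound 2 than to compound 3. Within the data shown here, the only single-place step known is a 2.3-fold lower number from compound 1 to compound 2 (0.37 log units; beyond the scatter). Compound 4 `COc1ccccc1N1CCN(CCCNC(=O)c2cc3ccc(Br)cc3[nH]2)CC1` carries the change (6-bromo-1H-indol-2-yl in place of (1H-indol-3-yl)methyl on a carbonyl carbon). Among the measured compounds shown here, no measured step matches it, but compound 3, which also joins an indole directly to the carbonyl, gives 1450 nM, whereas compound 1 gives 513 nM. Compound 4 is therefore expected to move toward a higher number, with a 1.9-fold higher number from compound 1 to compound 4 (0.29 log units; within the scatter). The estimate for compound 4 in this assay is 1000 nM, within 350 nM to 3000 nM.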

Compound 4, dissociation constant: 209 nM
Estimate against measurement, compound 4: 4.8-fold (0.68 log units) above; measured number below the stated range.
By their numbers in this assay, from the lowest: compounds 4 and 2 (each within the scatter of the next); then compound 1; then compound 3.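

In this assay, the change to 6-bromo-1H-indol-2-yl on this carbonyl carbon gives a 2.5-fold lower number from compound 1 to compound 4 (0.39 log units; beyond the scatter), and compound 4 stands within the scatter of compound 2. An indole bound directly to the carbonyl therefore does not by itself give a high number, even though compound 3, which goes against such a pattern, gives 1450 nM. Nothing available here explains this result.

The compounds shown do not separate the bromine from the change of indole attachment. From the compounds shown here alone, whether an unsubstituted 1H-indol-2-yl, or chlorine in place of bromine, would give a similar number remains open.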